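This account rests on a few compounds, and the source may have more. Where it says the series, first, only, none or still open, it means among the compounds named here.

Measured so far in an ADME assay on RAW264.7 cells (Mus musculus) for cytotoxicity, read by MTT assay, with a stated time of 48 h; a higher number here means that more compound is tolerated, a lower number that less compound is tolerated:
compound 1 `CC(=O)OC[C@H]1O[C@H](OC[C@@H](Cn2cc(CN(c3nc(-c4ccc(C)cc4)no3)C3CCCCC3)nn2)OC(C)=O)C=C[C@@H]1OC(C)=O` gives 45.3 ug/mL
compound 2 `C#CCN(c1nc(-c2ccccc2)no1)C1CCCCC1` gives 32.1 ug/mL
compound 3 `C#CCN(c1nc(-c2ccc(F)cc2)no1)C1CCCCC1` gives 20.9 ug/mL

Compound 1 carries the highest of the three numbers in this assay. Its gap to compound 2 is within the scatter, so no order can be read between those two; its gap to compound 3 is beyond the scatter. Going by the values given here, only one step between measured compounds is available, and it runs between the two smaller analogues rather than through the full glycoside: a 1.5-fold lower number from compound 2 to compound 3 (0.19 log units; within the scatter). Among the compounds with values here, no measured step touches the glycoside side of compound 1.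

Compound 4 `CC(=O)OC[C@H]1O[C@H](OC[C@@H](Cn2cc(CN(c3nc(-c4cccc([N+](=O)[O-])c4)no3)C3CCCCC3)nn2)OC(C)=O)C=C[C@@H]1OC(C)=O` is the next compound to be measured. (3-nitrophenyl in place of 4-methylphenyl on an aromatic carbon). Within the data shown here, the one step that bears on it is the aromatic substitution a 1.5-fold lower number from compound 2 to compound 3 (0.19 log units; within the scatter), which stayed within the scatter, and no measured compound carries a 3-nitrophenyl, so there is no precedent for the entering group itself. Among the measured compounds shown here, with no measured step showing a direction beyond the scatter for a change on this aromatic ring, the step of a 1.1-fold lower number from compound 1 to compound 4 (0.05 log units; within the scatter) is expected to be small and without a clear direction. Compound 4 is therefore estimated at 40 ug/mL in this assay, with a range from 20 ug/mL to 80 ug/mL.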

Compound 4, half-maximal cytotoxic concentration: 100 ug/mL
Compound 4: middle estimate off by 2.5-fold (0.40 log units), on the low side; the whole stated range lies below it.
By their numbers in this assay, from the lowest: compounds 3, 2 and 1 (each within the scatter of the next, the first and the last beyond it); then compound 4.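

Going by these compounds alone, at the aryl position, on the carbon between two ring nitrogen atoms and with the glycoside side held constant, this assay gives the first step beyond the scatter for a change on this aromatic group: a 2.2-fold higher number from compound 1 to compound 4 (0.34 log units; beyond the scatter), with 3-nitrophenyl in place of 4-methylphenyl. Within the data shown here, the only earlier aromatic step, a 1.5-fold lower number from compound 2 to compound 3 (0.19 log units; within the scatter), stayed within the scatter and ran between the smaller analogues, so it gave no readable direction and said nothing about the full glycoside; this modest step shows that an exchange at this place on the glycoside can raise the tolerated concentration. The data shown offer no explanation for this rise.

From the compounds shown here alone, the step exchanges the substituent and its place on the phenyl ring together, so it stays open whether the nitro group or its place carries the step, a question that a 4-nitrophenyl or a 3-methylphenyl analogue on the same core would separate. Also open, going by these compounds, is whether the same exchange holds on the smaller analogues without the glycoside, and whether an aminophenyl or a carboxyphenyl group at this place would move the number the same way.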